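Oxolane Ring in Place of a Methoxy Chain on the Core

A few compounds are considered here, and "the series" means these few. Any claim that something is new, unique, unknown or untested is made for them only; others in the source may bear on it.

The study measures a small set of compounds in an assay on cells with melanin-concentrating hormone receptor 1 (Homo sapiens) as the target, read by radioligand binding; a higher number here means a weaker inhibitor, a lower number a stronger inhibitor. Compound 1, `Nc1ccc2cccc(OC3CCCC3)c2n1`, gives > 2000 nM in this assay, which is a limit rather than a number. Compound 2, `COC(C)(C)CCOc1cccc2ccc(N)nc12`, gives 132 nM in this assay. Going by the values given here, compound 2 thus stands as the only compound with a number of its own, since the one further result, (the limit of > 2000 nM in this assay, at which 1 of the 2 values shown sits), is a limit.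

Compound 3, `Nc1ccc2cccc(OCC3CCOC3)c2n1`, has not yet been measured in this assay. It differs from compound 2 in one place: oxolan-3-yl in place of 2-methoxy-2-methylpropyl on a saturated chain carbon bound to an oxygen on an aromatic ring. Among the compounds with values here, no measured pair of compounds shows a step of this kind, so the size of the change can only be guessed. The chain of compound 2 is exchanged for a ring, and the expectation is a moderate loss, not a gain, with a step from compound 2 of a 3.0-fold higher number from compound 2 to compound 3 (0.48 log units; beyond the scatter) expected. Compound 3 is therefore expected to give about 400 nM in this assay, within a range from 120 nM to 1500 nM.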

Compound 3, half-maximal inhibitory concentration: 115 nM
Beside the measured number, compound 3's estimate is 3.5-fold (0.54 log units) above it; measured number outside the range, below it.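

In this assay, oxolan-3-yl in place of 2-methoxy-2-methylpropyl on a saturated chain carbon bound to an oxygen on an aromatic ring gives a 1.1-fold lower number from compound 2 to compound 3 (0.06 log units; within the scatter), so at this place a five-membered non-aromatic ring can stand in for an open chain with no readable change in the number. The other comparison, (oxolan-3-yl)methyl in place of cyclopentyl on an oxygen on an aromatic ring, gives an at least 17-fold lower number from compound 1 to compound 3 (1.24 log units; beyond the scatter), which shows that the presence of a ring on this oxygen does not by itself settle the result. The result for compound 1 is a limit and not a number, so this step has no fixed size: the limit of > 2000 nM in this assay, at which 1 of the 3 values shown sits.

The compounds shown leave open how (cyclopentyl)methyl would read on the same oxygen, a group that would help separate the part played by the ring oxygen of (oxolan-3-yl)methyl from that of its chain carbon. They also leave open whether a ring amine such as pyrrolidin-3-yl, or a longer chain ending in a methoxy group, would hold the number of compound 3.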